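A few compounds are considered here, and "the series" means these few. Any claim that something is new, unique, unknown or untested is made for them only; others in the source may bear on it.

Working notes on the series, in a functional assay on L6 cells (Rattus norvegicus) for inhibition; on this read-out higher numbers stand for weaker inhibition and lower numbers for stronger inhibition. Compound 1 `CC(C)c1c(C(=O)NCc2ccccc2)nn(-c2ccc(F)cc2)c1OC[C@@H](O)C[C@@H](O)CC(=O)O`, the plain benzyl amide of the shared core, gives 880 nM. Compound 2 `CC(C)c1c(C(=O)N2CCCC2c2ccccc2)nn(-c2ccc(F)cc2)c1OC[C@@H](O)C[C@@H](O)CC(=O)O` gives 4340 nM. Compound 3 `CC(C)c1c(C(=O)NCc2cccc(Cl)c2)nn(-c2ccc(F)cc2)c1OC[C@@H](O)C[C@@H](O)CC(=O)O` has no usable number, its entry reading "not determined" (no result reported), so it offers no anchor on the scale.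

The next compound is compound 4 `CC(C)c1c(C(=O)N(C)Cc2cccc(F)c2)nn(-c2ccc(F)cc2)c1OC[C@@H](O)C[C@@H](O)CC(=O)O`. Its change from compound 3 is (3-fluorobenzyl)(methyl)amino in place of (3-chlorobenzyl)amino on a carbonyl carbon. The amide hydrogen is lost, and the ring substituent changes from chlorine to fluorine.

Going by the values given here, only one measured step bears on this, and only in part: a 4.9-fold higher number from compound 1 to compound 2 (0.69 log units; beyond the scatter). That step, with 2-phenylpyrrolidin-1-yl in place of benzylamino, also removes the amide hydrogen, and it is modest in size. Among the compounds with values here, no measured step isolates the methyl group or the exchange of chlorine for fluorine, and one step cannot establish a trend.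

With compound 3 unavailable, compound 1 at 880 nM serves as the reference. A modest move to a higher number in this assay, meaning weaker inhibition, is expected, probably no larger than the measured step. For compound 4 the estimated value is 1800 nM, with an expected range of 550 nM to 5500 nM.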

Compound 4, half-maximal inhibitory concentration: 2470 nM
Compound 4: the middle estimate sits 1.4-fold (0.14 log units) below what was measured; measured number inside the range.
By their numbers in this assay, from the lowest: compound 1; then compounds 4 and 2 (each within the scatter of the next).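

Going by these compounds alone, compound 3 has no number, so the step to compound 4 cannot be read, but in this assay there is now a second replacement of benzylamino by a group without the amide hydrogen, and a 2.8-fold higher number from compound 1 to compound 4 (0.45 log units; beyond the scatter) shows that both such amides measured so far give higher numbers than compound 1, with no measured compound going against this. Between the two amides without that hydrogen, a 1.8-fold lower number from compound 2 to compound 4 (0.24 log units; within the scatter), so the open (3-fluorobenzyl)(methyl)amino group and the ring-closed 2-phenylpyrrolidin-1-yl group cannot be told apart on this read-out. No available information accounts for these differences.

Compound 4 differs from compound 1 by both the methyl group and the ring fluorine, so their separate contributions remain unresolved, and loss of the amide hydrogen is still not isolated from the other changes at this position. Benzyl(methyl)amino and (3-fluorobenzyl)amino would split that pair of changes, while the open question of the ring halogen would need (3-chlorobenzyl)(methyl)amino or a usable number for compound 3.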